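A Phenyl Swap and Cell Tolerance in Compound 3

The source may report more compounds than this note shows. Statements on the series, on what has been measured and on what is new or still open speak of the compounds shown alone.

Going by the values given here, two related compounds have numbers so far. In an ADME assay on MT2 cells (Homo sapiens) for cytotoxicity, read by XTT assay, with a stated time of 4 days (a higher number here means that more compound is tolerated, a lower number that less compound is tolerated), compound 1 (`Cc1nc(C(NC(=O)C(=O)Nc2ccc(Cl)cc2)C2CCCN2)sc1CCO`) gives 42000 nM, while compound 2 (`Cc1nc(C(NC(=O)C(=O)Nc2ccc(F)c(Cl)c2)C2CCCCN2)sc1CCO`) gives 94700 nM. Compound 2 therefore stands as the higher of the two, and the gap between them is beyond the usual scatter of repeated measurements.

Compound 3 (`Cc1nc(C(NC(=O)C(=O)Nc2ccc(Cl)cc2)C2CCCCN2)sc1CCO`) has not yet been measured. It differs from compound 2 in one place: 4-chlorophenyl in place of 3-chloro-4-fluorophenyl on an amide-type nitrogen. In words, it has 4-chlorophenyl in place of 3-chloro-4-fluorophenyl on an amide-type nitrogen.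

Among the compounds with values here, no measured pair shows this change in isolation, so any forecast is loose. Compound 1 also carries the 4-chlorophenyl and gives 42000 nM, but the two compounds are not otherwise identical. A small move toward a lower number in this assay is therefore expected, probably no larger than the scatter. The estimated change is a 1.4-fold lower number from compound 2 to compound 3 (0.13 log units; within the scatter). For compound 3, the expected value is 70000 nM, with an estimated range from 35000 nM to 130000 nM.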

Compound 3, half-maximal cytotoxic concentration: > 62000 nM
Compound 3: no number, only a limit; the forecaster's own chance of this, stated with the estimate: 15%; the middle value is on the limit's open side.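

For compound 3, the result in this assay is a limit and not a number: the limit of > 62000 nM in this assay, at which 1 of the 3 values shown sits.

The step from compound 2 to compound 3 cannot be read, so replacing 3-chloro-4-fluorophenyl with 4-chlorophenyl on an amide-type nitrogen still has no measured size, either large or small. Going by these compounds alone, the result does give the first comparison in which only one place changes: piperidin-2-yl in place of pyrrolidin-2-yl on a saturated chain carbon bound to an amide-type nitrogen and an aromatic carbon gives an at least 1.4-fold higher number from compound 1 to compound 3 (0.16 log units; that floor lies within the scatter). This sets only a floor, and because that floor is within the scatter, the pair does not establish a real gap, although the true gap could be larger.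

From the compounds shown here alone, it remains open whether losing the fluorine from the phenyl ring changes how much compound the cells tolerate, since that would need a number for compound 3 rather than a limit. Also open, going by these compounds, is how an unsubstituted phenyl on the amide-type nitrogen, or an open-chain amine in place of piperidin-2-yl, would read in this assay.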